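Bringing a Ring Nitrogen into the Cyclohexyl Group

The compounds below may be only part of what the source reports. "The series", "measured", "known", "first", "only" and "open" are said of these compounds alone.

The three measured compounds share one core and differ only in the group on an aromatic nitrogen. Compound 1 `CC(C)n1nc(C(=O)N[C@H]2COc3ccccc3N(C)C2=S)nc1Cc1ccccc1` carries isopropyl there and in a functional assay on HT-29 cells (Homo sapiens) for inhibition, read by luminescence and CellTiter-Glo, with a stated time of 24 h (on this read-out higher numbers stand for an effect only at larger amounts of compound and lower numbers for an effect already at smaller amounts), compound 1 gives 360 nM. Compound 2 `CN1C(=S)[C@@H](NC(=O)c2nc(Cc3ccccc3)n(CCCF)n2)COc2ccccc21` carries 3-fluoropropyl and gives 4760 nM in this assay; compound 3 `CN1C(=S)[C@@H](NC(=O)c2nc(Cc3ccccc3)n(C3CCCCC3)n2)COc2ccccc21` carries cyclohexyl and gives 4000 nM. Compound 3 thus stands second highest of the three numbers: its nearest neighbour is compound 2, with a 1.2-fold lower number from compound 2 to compound 3 (0.08 log units; within the scatter) within the scatter, and its furthest is compound 1, with an 11-fold higher number from compound 1 to compound 3 (1.05 log units; beyond the scatter) beyond it.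

Compound 4 `CN1C(=S)[C@@H](NC(=O)c2nc(Cc3ccccc3)n(C3CCNCC3)n2)COc2ccccc21` differs from compound 3 by piperidin-4-yl in place of cyclohexyl on an aromatic nitrogen. For the measured compounds named here, two measured steps touch this position: a 13-fold higher number from compound 1 to compound 2 (1.12 log units; beyond the scatter) and an 11-fold higher number from compound 1 to compound 3 (1.05 log units; beyond the scatter) were both large, while a 1.2-fold lower number from compound 2 to compound 3 (0.08 log units; within the scatter) stayed within the scatter. Going by the values given here, no measured step introduces a hydrogen-bond donor or acceptor into this group, so there is no direct precedent. Compound 4 is therefore expected to show a step of a 1.3-fold higher number from compound 3 to compound 4 (0.10 log units; within the scatter) that does not clearly exceed the scatter. Compound 4 is estimated at 5000 nM, with a range from 1500 nM to 16000 nM.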

Compound 4, half-maximal effective concentration: 1000 nM
For compound 4 the middle estimate is 5.0-fold (0.70 log units) above the measured one; the whole stated range lies above it.
By their numbers in this assay, from the lowest: compound 1; then compound 4; then compounds 3 and 2 (each within the scatter of the next).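

Replacing one ring carbon of cyclohexyl with the nitrogen of piperidin-4-yl, with the ring size and heavy-atom count unchanged, gives a 4.0-fold lower number from compound 3 to compound 4 (0.60 log units; beyond the scatter) in this assay, so this position responds to a change within the ring itself. Compounds 2 and 3 had stood within the scatter of each other, but the new group gives a 4.8-fold lower number from compound 2 to compound 4 (0.68 log units; beyond the scatter), while isopropyl stays ahead with a 2.8-fold higher number from compound 1 to compound 4 (0.44 log units; beyond the scatter), so piperidin-4-yl recovers only part of the gap to compound 1. Nothing available here explains this gain.

The compounds shown leave open whether the gain needs the hydrogen on the ring nitrogen, which 1-methylpiperidin-4-yl or tetrahydropyran-4-yl would test. From the compounds shown here alone, it also remains open whether an open-chain amine such as 3-aminopropyl or a smaller azetidin-3-yl ring would come closer to compound 1.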